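This account rests on a few compounds, and the source may have more. Where it says the series, first, only, none or still open, it means among the compounds named here.

In a functional assay on HBL-100 cells (Homo sapiens) for antiproliferative activity, read by sulforhodamine B assay, with a stated time of 48 h (on this read-out higher numbers stand for weaker inhibition of growth and lower numbers for stronger inhibition of growth), compound 1 (`CCCCCCC(C#CC(=O)OC)O/C=C/C(=O)OC`) gives 2500 nM and compound 2 (`COC(=O)C#CC(O/C=C/C(=O)OC)C1CCCCC1`) gives 2500 nM. Among the compounds with values here, compound 2 therefore stands level with compound 1, its only measured neighbour. The next structure is compound 3 (`COC(=O)C#CC(CC(C)C)O/C=C/C(=O)OC`), with isobutyl in place of cyclohexyl on a saturated chain carbon bound to an oxygen on an unsaturated carbon and a triple-bonded carbon. Within the data shown here, one measured step bears on this change, the exchange of hexyl for cyclohexyl at the same place, and it reads no change at the digits printed from compound 1 to compound 2 (within the scatter). Among the measured compounds shown here, that single step is the only guide, and no isobutyl compound has been measured yet. The data give no direction for a move in this assay, so no step beyond the scatter is expected on going from cyclohexyl to isobutyl. The expected size is no change at the digits printed from compound 2 to compound 3 (within the scatter). Compound 3 is estimated at 2500 nM, with an expected range from 1300 nM to 5000 nM.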

Compound 3, concentration for 50% growth inhibition: 330 nM
For compound 3 the middle estimate is 7.6-fold (0.88 log units) above the measured one, and the stated range ends above it.
By their numbers in this assay, from the lowest: compound 3; then compounds 1 and 2 (each within the scatter of the next).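

In this assay the position, a saturated chain carbon bound to an oxygen on an unsaturated carbon and a triple-bonded carbon, proves sensitive to the group it carries: isobutyl in place of cyclohexyl gives a 7.6-fold lower number from compound 2 to compound 3 (0.88 log units; beyond the scatter). The same holds against the hexyl compound, with a 7.6-fold lower number from compound 1 to compound 3 (0.88 log units; beyond the scatter), so the level reading of hexyl and cyclohexyl did not mean that the position tolerates any carbon group equally, and isobutyl alone separates from the other two. Nothing measured here accounts for this separation.

Going by these compounds, with only these three groups, it remains open whether the lower number goes with the branching of isobutyl, with its chain size or with the absence of a ring, since isobutyl differs from hexyl and from cyclohexyl in more than one of these respects. On these data alone, a straight butyl chain, a cyclopentyl ring or a phenyl ring at the same place would help to separate these readings, and how far the lower number extends to other branched chains also remains open.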